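Swapping a halogen on the phenyl ring: chloro to fluoro

The source may hold more compounds than are shown below. What is called first, only, known or untested is meant among the compounds shown, and "the series" means these compounds.

Measured compounds in a functional assay on HeLa cells (Homo sapiens) for cytotoxicity, read by MTT assay, with a stated time of 48 h; a lower number here means a stronger inhibitor, a higher number a weaker inhibitor:
Compound 1 `COC(=O)c1c(-c2cc3ccccc3oc2=O)nn(-c2ccccc2)c1C(=O)OC` gives 35000 nM.
Compound 2 `COC(=O)c1c(-c2cc3ccccc3oc2=O)nn(-c2cccc(C)c2)c1C(=O)OC` gives 45000 nM.
Compound 3 `COC(=O)c1c(-c2cc3ccccc3oc2=O)nn(-c2cccc(Cl)c2)c1C(=O)OC` gives 76000 nM.

Compound 3 has the highest number of the three, so it is the weakest inhibitor among them, though its gap to compound 2 lies within the scatter; only its gap to compound 1 is beyond it, as a 2.2-fold higher number from compound 1 to compound 3 (0.34 log units; beyond the scatter). Compound 4 `COC(=O)c1c(-c2cc3ccccc3oc2=O)nn(-c2cccc(F)c2)c1C(=O)OC` differs from compound 3 in a single place: fluoro in place of chloro on an aromatic carbon.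

Among the measured compounds shown here, no measured step swaps one halogen for another, so the closest guides are the two steps that bring chloro in: a 2.2-fold higher number from compound 1 to compound 3 (0.34 log units; beyond the scatter) and a 1.7-fold higher number from compound 2 to compound 3 (0.23 log units; within the scatter). Both raised the number, the first beyond the scatter, the second within it. Removing chloro for another single-atom group is expected to undo only part of that, giving a modest lower number, probably within the scatter, as a 1.5-fold lower number from compound 3 to compound 4 (0.18 log units; within the scatter). Compound 4 is therefore estimated at 50000 nM, in the range 25000 nM to 100000 nM.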

Compound 4, half-maximal inhibitory concentration: 76000 nM
For compound 4 the middle estimate is 1.5-fold (0.18 log units) below the measured one, within the range that was stated.
By their numbers in this assay, from the lowest: compounds 1, 2, 3 and 4 (each within the scatter of the next, the first and the last beyond it).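

In this assay, going from 3-chlorophenyl to 3-fluorophenyl leaves the reading where it was (no change at the digits printed from compound 3 to compound 4 (within the scatter)), so at this position the two halogens cannot be told apart. Fluoro also repeats what chloro did against the other two groups, with one step beyond the scatter (a 2.2-fold higher number from compound 1 to compound 4 (0.34 log units; beyond the scatter)) and one within it (a 1.7-fold higher number from compound 2 to compound 4 (0.23 log units; within the scatter)). Both halogens therefore stand modestly apart from the plain phenyl of compound 1, while the methyl of compound 2 stays within the scatter of all three others.

Nothing reported alongside these numbers bears on why chloro and fluoro match. From the compounds shown here alone, whether an amine or a carboxylic acid on this same aromatic carbon would move the number away from this narrow band remains open.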